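This account rests on a few compounds, and the source may have more. Where it says the series, first, only, none or still open, it means among the compounds named here.

In a functional assay on HCT-116 cells (Homo sapiens) for inhibition, read by sulforhodamine B assay, with a stated time of 48 h, tested at 50 uM (on this read-out higher numbers stand for more inhibition of growth at the one concentration tested and lower numbers for less inhibition of growth), three related compounds have been measured so far. Compound 1 `COc1cccc(/C=C/C(=O)/C=C/c2ccc(OCc3cn(CCCCCOc4cc(=O)oc5ccccc45)nn3)c(OC)c2)c1` gives 36%, the lowest of the three numbers. Compound 2 `COc1cc(/C=C/C(=O)/C=C/c2cc(OC)c(OC)c(OC)c2)ccc1OCc1cn(CCCCOc2cc(=O)oc3ccccc23)nn1` gives 63% and compound 3 `COc1cc(/C=C/C(=O)/C=C/c2ccco2)ccc1OCc1cn(CCOc2cc(=O)oc3ccccc23)nn1` gives 72%, and both lie beyond the usual scatter from compound 1.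

Compound 4 `COc1cc(/C=C/C(=O)/C=C/c2cc(OC)c(OC)c(OC)c2)ccc1OCc1cn(CCCCCOc2cc(=O)oc3ccccc23)nn1` has not been measured yet. It differs from compound 1 in one place: 3,4,5-trimethoxyphenyl in place of 3-methoxyphenyl on a double-bonded chain carbon bound to a double-bonded chain carbon. For the measured compounds named here, no two measured compounds differ in only one place, so the size of this step cannot be read directly from the data. Going by the values given here, the only guide is compound 2, which also carries 3,4,5-trimethoxyphenyl and gives 63%. A moderate rise is therefore expected, estimated as a number 14 percentage points higher from compound 1 to compound 4 (beyond the scatter) in this assay. Compound 4 is expected to give about 50%, with an estimated range of 33% to 68%.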

Compound 4, percent growth inhibition at one concentration: 53%
Beside the measured number, compound 4's estimate is 3 percentage points below it; low and high end bracket the measured number.
By their numbers in this assay, from the lowest: compound 1; then compounds 4, 2 and 3 (each within the scatter of the next, the first and the last beyond it).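

Within this assay the exchange of 3-methoxyphenyl for 3,4,5-trimethoxyphenyl gives a number 17 percentage points higher from compound 1 to compound 4 (beyond the scatter) with the rest of the molecule unchanged, the first direct reading of a change at this position. It shows that the aromatic group on a double-bonded chain carbon bound to a double-bonded chain carbon can, on its own, shift growth inhibition by more than the usual scatter. Nothing measured here explains this rise.

As far as these compounds go, it remains open whether the rise depends on one particular methoxy group or on all three together, and whether the same exchange would have a similar effect on a shorter chain. From the compounds shown here alone, how a phenyl ring carrying an amine or a carboxylic acid would behave at this position also remains open.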